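Amide Replacement on the Piperidine Sulfonamide Core

The source may report more compounds than this note shows. Statements on the series, on what has been measured and on what is new or still open speak of the compounds shown alone.

Measured so far:
compound 1 `CCN(CC)S(=O)(=O)c1ccc(S(=O)(=O)N2CCC[C@@H](C(=O)NC3CCOCC3)C2)cc1`, 8570 nM
compound 2 `CCN(CC)C(=O)c1ccc(S(=O)(=O)N2CCC[C@@H](C(=O)N3CCC(F)(F)CC3)C2)cc1`, 240 nM

In a functional assay on BXPC-3 cells (Homo sapiens) for inhibition, read by MTT assay, with a stated time of 7 days (on this read-out lower numbers stand for stronger inhibition and higher numbers for weaker inhibition), compound 1 gives 8570 nM, the higher of the two numbers; compound 2 gives 240 nM, a gap well beyond the scatter. Compound 1 and compound 2 differ in more than one place, so their gap cannot be read as a single step. Compound 3 `CCN(CC)S(=O)(=O)c1ccc(S(=O)(=O)N2CCC[C@@H](C(=O)N3CCS(=O)(=O)CC3)C2)cc1` is unmeasured and differs from compound 1 by 1,1-dioxothiomorpholin-4-yl in place of (oxan-4-yl)amino on a carbonyl carbon. Without a comparable step on record, the change is expected to lower the number by a modest amount, a 2.4-fold lower number from compound 1 to compound 3 (0.39 log units; beyond the scatter). Compound 3 is accordingly estimated at 3500 nM, with a range from 900 nM to 14000 nM.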

Compound 3, half-maximal inhibitory concentration: 4430 nM
Estimate against measurement, compound 3: 1.3-fold (0.10 log units) below; the range from low to high includes it.
By their numbers in this assay, from the lowest: compound 2; then compounds 3 and 1 (each within the scatter of the next).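

For the compounds shown here, at this carbonyl carbon, 1,1-dioxothiomorpholin-4-yl in place of (oxan-4-yl)amino gives a 1.9-fold lower number from compound 1 to compound 3 (0.29 log units; within the scatter), the first single-place step on record for this series. The entering group has no hydrogen-bond donor and the leaving group has one, yet this exchange of two quite different rings leaves compound 1 and compound 3 within the scatter of each other. Nothing on record bears on why this is so.

From the compounds shown here alone, whether this position would respond to a plain morpholine, a piperazine or an open-chain dialkylamine on the same core remains open.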